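From a Hexyl Chain to an Acetyl Group

The compounds below may be only part of what the source reports. "The series", "measured", "known", "first", "only" and "open" are said of these compounds alone.

Measured so far:
compound 1 `CCCCc1ccc(Nc2nc3nonc3nc2O)cc1`: 2100 nM
compound 2 `CCCCCCc1ccc(Nc2nc3nonc3nc2O)cc1`: 4700 nM

In an assay on mitochondria from L6 cells (Rattus norvegicus) for activation, with a stated time of 90 min (on this read-out higher numbers stand for an effect only at larger amounts of compound and lower numbers for an effect already at smaller amounts), compound 1 gives 2100 nM and compound 2 gives 4700 nM. Among the compounds with values here, compound 2 thus stands at the higher of the two numbers; the only measured step, a 2.2-fold higher number from compound 1 to compound 2 (0.35 log units; beyond the scatter), came from lengthening the chain on the aromatic ring. Compound 3 `CC(=O)c1ccc(Nc2nc3nonc3nc2O)cc1` now removes that chain altogether: acetyl in place of hexyl on an aromatic carbon. Within the data shown here, no measured step shows what a carbonyl-bearing group at this position does, so the single step is a weak guide. It shows only that a longer chain gave a higher number, which leaves room for a shorter substituent to return toward the number of compound 1, with wide uncertainty. The expected step is a 1.9-fold lower number from compound 2 to compound 3 (0.27 log units; within the scatter). Compound 3 is therefore estimated at 2500 nM, within a range from 500 nM to 15000 nM.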

Compound 3, half-maximal effective concentration: 93700 nM
Estimate against measurement, compound 3: 37-fold (1.57 log units) below, outside the stated range (above it).
By their numbers in this assay, from the lowest: compound 1; then compound 2; then compound 3.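

In this assay, replacing the chain with acetyl gives a 20-fold higher number from compound 2 to compound 3 (1.30 log units; beyond the scatter) and, measured against the shorter butyl chain, a 45-fold higher number from compound 1 to compound 3 (1.65 log units; beyond the scatter) for the same kind of change. Both steps are far larger than a 2.2-fold higher number from compound 1 to compound 2 (0.35 log units; beyond the scatter) seen on lengthening the chain, so this aromatic carbon is much more sensitive to the kind of group placed on it than the two chains alone could show. Nothing measured here explains the jump.

Acetyl differs from butyl and hexyl in both its shorter length and its carbonyl, so these compounds cannot separate the two changes. A propyl chain would test shortening without a carbonyl, while an amide or a carboxylic acid would show whether other carbonyl-bearing groups at this place behave like acetyl.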